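From Cyclopropyl to Methyl on Compound 2

The compounds below may be only part of what the source reports. "The series", "measured", "known", "first", "only" and "open" are said of these compounds alone.

Among the measured compounds shown here, only two measurements are available so far. In a physicochemical assay for solubility, measured as thermodynamic solubility, at pH 4 (a higher number here means a more soluble compound, a lower number a less soluble compound), compound 1 (`CN1C(=O)C2=C(C1=O)N(CC(=O)Nc1ccc(-c3cccnc3)nn1)CCC2`) gives 13.9 ug/mL, an exact reading. Compound 2 (`Cc1ccc(-c2ccc(NC(=O)CN3CCCC4=C3C(=O)N(C3CC3)C4=O)nn2)cn1`) gives > 41 ug/mL, which is a limit of the assay and not a number. Compound 2 therefore stands at the limit of > 41 ug/mL in this assay, at which 1 of the 2 values shown sits.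

The next molecule, compound 3 (`Cc1ccc(-c2ccc(NC(=O)CN3CCCC4=C3C(=O)N(C)C4=O)nn2)cn1`), makes one change to compound 2: methyl in place of cyclopropyl on an amide-type nitrogen in a ring. For the measured compounds named here, no measured pair of compounds shows this change on its own, so any forecast is uncertain. In this assay, a modest fall is expected, and the estimated change is an at least 1.3-fold lower number from compound 2 to compound 3 (0.13 log units; that floor lies within the scatter). Going by the values given here, this expectation leans on compound 1, whose 13.9 ug/mL is the only exact value so far. The estimate for compound 3 is 30 ug/mL, with an expected range of 12 ug/mL to 75 ug/mL.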

Compound 3, solubility: > 194 ug/mL
Compound 3 was reported as a limit; the forecaster's own chance of this, stated with the estimate: 30%; middle value at least 6.4-fold (0.81 log units) away from the limit.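

With methyl on the amide-type nitrogen in a ring, compound 3 gives > 194 ug/mL in this assay, which is a limit of the assay and not a number. Compound 2, with cyclopropyl at that place, gives > 41 ug/mL, also a limit, so the step between these two compounds cannot be read, neither its size nor its direction. Among the compounds shown here, the one readable step is an at least 13-fold higher number from compound 1 to compound 3 (1.14 log units; beyond the scatter), and it comes with methyl in place of hydrogen on an aromatic carbon, a change that no earlier pair showed.

On these data alone, the exact values of compound 2 and compound 3 stay open, so cyclopropyl and methyl cannot be ranked at this place. Also open, as far as these compounds go, is how a group such as an amine or a carboxylic acid would read on that amide-type nitrogen.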